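A few compounds are considered here, and "the series" means these few. Any claim that something is new, unique, unknown or untested is made for them only; others in the source may bear on it.

Measured so far:
compound 1, `Cc1c(OCCCCOc2ccc(C(=O)O)cc2Cl)ccc(C(=O)CC2CCCC2)c1O`: 27.4%
compound 2, `Cc1c(OCCCCOc2ccc(C(=O)O)cc2Cl)ccc(C(=O)CC(C)C)c1O`: 62.9%

Both were tested in an assay on HEK293 cells for positive allosteric modulation of metabotropic glutamate receptor 3 (Rattus norvegicus), read by thallium flux, with a stated time of 2.5 min; on this read-out higher numbers stand for larger maximal responses and lower numbers for smaller maximal responses. Compound 1 gives 27.4% and stands lowest of the two numbers. For the measured compounds named here, compound 2 gives 62.9%, and the only measured step is a number 35.5 percentage points higher from compound 1 to compound 2 (beyond the scatter). That step swaps the group on a saturated chain carbon bound to a carbonyl carbon and leaves the rest untouched.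

Compound 3, `Cc1cc(OCCCCOc2ccc(C(=O)CC3CCCC3)c(O)c2C)ccc1C(=O)O`, differs from compound 1 at another place: 4-carboxy-3-methylphenyl in place of 4-carboxy-2-chlorophenyl on an oxygen on a saturated carbon. Going by the values given here, no measured pair alters this part of the molecule, so the single known step gives no guide to direction or size for this change. The expectation for compound 3 is therefore anchored on compound 1 with a wide range, and the expected step is a number 2.6 percentage points higher from compound 1 to compound 3 (within the scatter), which means no step beyond the scatter is expected. Compound 3 is estimated at 30% in this assay, expected to fall between 10% and 60%.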

Compound 3, largest response reached (reported as percent of maximum), in percent of the reference or control that the assay uses: 23.7%
The estimate for compound 3 lay 6.3 percentage points above the measured number; the measured number falls inside the stated range.
By their numbers in this assay, from the lowest: compounds 3 and 1 (each within the scatter of the next); then compound 2.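

In this assay, 4-carboxy-3-methylphenyl in place of 4-carboxy-2-chlorophenyl on an oxygen on a saturated carbon gives a number 3.7 percentage points lower from compound 1 to compound 3 (within the scatter), so with the cyclopentyl group present, this exchange leaves the maximal response unchanged. The only earlier step, a number 35.5 percentage points higher from compound 1 to compound 2 (beyond the scatter), came from a different place, the group on a saturated chain carbon bound to a carbonyl carbon, so among these three compounds only that change has moved the response beyond the scatter. No measurement here explains why the exchange of these two groups makes no clear difference.

Going by these compounds, it remains open whether the same exchange would also leave the response unchanged in compound 2, which carries isopropyl instead of cyclopentyl. Also open, on these data alone, is what a tetrazole in place of the carboxylic acid on this ring would do.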